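A few compounds are considered here, and "the series" means these few. Any claim that something is new, unique, unknown or untested is made for them only; others in the source may bear on it.

Compound 1 `O=C(N[C@H]1CCOC[C@@H]1O)c1cn(Cc2ccc(-c3cc[nH]n3)cc2)c2cccnc12`: 9.2 mL/min/kg
Compound 2 `CN(C)C(=O)CNC(=O)c1cn(Cc2ccc(-n3cccn3)cc2)c2cccnc12`: 9.3 mL/min/kg

Both numbers come from an ADME assay on liver for metabolic stability, with Liver microsome (Homo sapiens) as the target, using microsomes; a higher number here means faster removal of the compound, a lower number slower removal. Compound 2 gives 9.3 mL/min/kg and compound 1 gives 9.2 mL/min/kg; the two lie within the usual scatter of each other, so neither can be set apart from the other on these figures. Compound 3 `O=C(N[C@H]1CC[C@H](CO)CC1)c1cn(Cc2ccc(-n3cccn3)cc2)c2cccnc12` is not yet measured. It differs from compound 2 in one place: 4-(hydroxymethyl)cyclohexyl in place of (dimethylcarbamoyl)methyl on an amide-type nitrogen. Among the compounds with values here, no measured pair shows this kind of change, so there is no direct guide. The step from compound 2 to compound 3 is expected to be a 1.3-fold higher number from compound 2 to compound 3 (0.11 log units; within the scatter), a small rise that may well stay within the scatter. Compound 3 is therefore estimated at 12 mL/min/kg, in a range from 6 mL/min/kg to 24 mL/min/kg.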

Compound 3, clearance: 8.5 mL/min/kg
Compound 3: middle estimate off by 1.4-fold (0.15 log units), on the high side; the range from low to high includes it.
By their numbers in this assay, from the lowest: compounds 3, 1 and 2 (each within the scatter of the next).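

In this assay the swap of (dimethylcarbamoyl)methyl for 4-(hydroxymethyl)cyclohexyl on the amide-type nitrogen gives a 1.1-fold lower number from compound 2 to compound 3 (0.04 log units; within the scatter) and so leaves the number where it was. At this position, then, an open chain can give way to a six-membered carbon ring bearing a hydrogen-bond donor with no visible shift in this read-out. Nothing measured here offers a reason for that. On these data alone, whether an amine or a carboxylic acid on this nitrogen would move the number beyond the scatter stays open. So does what a plain cyclohexyl, without the hydroxymethyl, would give.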